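Swapping trifluoromethyl for methyl: what cytotoxicity to expect

The compounds below may be only part of what the source reports. "The series", "measured", "known", "first", "only" and "open" are said of these compounds alone.

Measured so far in an ADME assay on cells (Macrophage, Mus musculus) for cytotoxicity, read by resazurin assay, with a stated time of 3 days; a lower number here means a stronger inhibitor, a higher number a weaker inhibitor:
compound 1, `O=C(Nc1cc(C(F)(F)F)cc(C(F)(F)F)c1)c1cccc(Cl)c1`
compound 2, `O=C(Nc1cc(C(F)(F)F)cc(C(F)(F)F)c1)c1cc(-n2cccc2)ccc1O`, 3100 nM
compound 3, `O=C(Nc1ccc(OC(F)(F)F)cc1)c1cc(Cl)ccc1O`, 7300 nM

Compound 1 gives no number, only the assay limit > 60000 nM (the limit of > 60000 nM in this assay, at which 1 of the 3 values shown sits). Among the two real numbers, compound 3 has the higher one, and the nearest, that of compound 2, lies below it by more than the usual scatter.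

Compound 4, `COc1ccc(NC(=O)c2cc(Cl)ccc2O)cc1`, is not yet measured. It differs from compound 3 by methyl in place of trifluoromethyl on an oxygen on an aromatic ring. Among the measured compounds shown here, no measured pair shows this change, so its effect is unknown here. A modest move toward a higher number is expected, a 1.6-fold higher number from compound 3 to compound 4 (0.22 log units; within the scatter), close to the scatter. Compound 4 is estimated at 12000 nM, between 4000 nM and 40000 nM.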

Compound 4, half-maximal inhibitory concentration: > 60000 nM
Compound 4 was reported as a limit (the forecaster's own chance of this, stated with the estimate: 15%); at least 5.0-fold (0.69 log units) between middle value and limit.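

In this assay, among the compounds shown here, methyl in place of trifluoromethyl on an oxygen on an aromatic ring gives an at least 8.2-fold higher number from compound 3 to compound 4 (0.91 log units; beyond the scatter) and is the first single change that can be read here. The group on this oxygen therefore matters for cytotoxicity in this pair, with the methoxy compound the weaker inhibitor. Compound 4 gives a limit and not a number, so the step shows only a minimum size: the limit of > 60000 nM in this assay, at which 2 of the 4 values shown sit.

As far as these compounds go, whether an ethyl chain on the same oxygen would sit nearer compound 3 or compound 4 stays open. So does the outcome with an amine in place of the trifluoromethoxy group.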